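Hydroxy for nitro on the core of compound 1

A few compounds are considered here, and "the series" means these few. Any claim that something is new, unique, unknown or untested is made for them only; others in the source may bear on it.

Compound 1 `O=[N+]([O-])c1ccc(Nc2ccc(N3CC4CC(C3)N4)cn2)cc1` is the weakest of the three measured compounds in an assay on HEK293 cells for displacement of a labelled ligand from Neuronal acetylcholine receptor; alpha3/beta4 (Homo sapiens) (a lower number here means a stronger inhibitor, a higher number a weaker inhibitor), giving 25 nM. Compound 2 `Clc1ccc(Nc2cncc(N3CC4CC(C3)N4)c2)cc1` gives 1.2 nM in this assay, and compound 3 `Oc1ccc(Nc2cncc(N3CC4CC(C3)N4)c2)cc1` gives 0.988 nM; both sit on a different core from compound 1, so their gap to compound 1 cannot be assigned to the aryl substituent alone.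

The step to compound 4 `Oc1ccc(Nc2ccc(N3CC4CC(C3)N4)cn2)cc1` replaces the nitro group: hydroxy in place of nitro on an aromatic carbon. Within the data shown here, no measured pair shows this exact exchange. The closest information is the step from compound 2 to compound 3, a 1.2-fold lower number from compound 2 to compound 3 (0.08 log units; within the scatter), where hydroxy replaced chloro on the same aromatic carbon and the number hardly moved. Among the measured compounds shown here, that pair says nothing directly about nitro, and no measured compound carries hydroxy on the core of compound 1.

On this basis only a modest change is expected for compound 4 in this assay, with wide uncertainty. The step expected for compound 4 is a 2.5-fold lower number from compound 1 to compound 4 (0.40 log units; beyond the scatter). The estimate for compound 4 is 10 nM, with a plausible range from 2.5 nM to 40 nM.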

Compound 4, inhibition constant: 165 nM
The estimate for compound 4 lay 17-fold (1.22 log units) below the measured number; measured number outside the range, above it.
By their numbers in this assay, from the lowest: compounds 3 and 2 (each within the scatter of the next); then compound 1; then compound 4.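

On the core of compound 1, the place para to a large group on the six-membered aromatic ring of carbon only does respond to its substituent: in this assay, hydroxy in place of nitro gives a 6.6-fold higher number from compound 1 to compound 4 (0.82 log units; beyond the scatter). Among these compounds, this is the first measured pair on this core, and it shows that hydroxy here gives a weaker inhibitor than nitro, a change beyond the usual scatter. The earlier exchange on the other core, hydroxy in place of chloro, gave a 1.2-fold lower number from compound 2 to compound 3 (0.08 log units; within the scatter), so that flat result does not carry over as a general rule for hydroxy at this place. Nothing available explains the rise in the number on this core.

The compounds shown leave open whether the contrast between the two steps comes from the group that leaves, nitro or chloro, or from the core, and chloro on the core of compound 1 would connect the two pairs directly. From the compounds shown here alone, how an amine, a methoxy group or a carboxylic acid at this place would read in this assay also remains open.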